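Moving the fluorine on the pendant phenyl of compound 1

The compounds below may be only part of what the source reports. "The series", "measured", "known", "first", "only" and "open" are said of these compounds alone.

Compound 1 `O=S(=O)(c1ccc(F)c(Cl)c1)c1cnc2cc(F)ccc2c1-c1cccc(F)c1`: 0.25 mL/min
Compound 2 `O=S(=O)(c1ccc(F)c(F)c1)c1cnc2cc(F)ccc2c1-c1cccc(F)c1`: 0.6 mL/min
Compound 3 `O=S(=O)(c1cc(Cl)cc(Cl)c1)c1cnc2cc(F)ccc2c1-c1cccc(F)c1`: 0.41 mL/min

In an ADME assay on microsomes from liver (Homo sapiens) for metabolic stability, tested at 2.5 uM (on this read-out lower numbers stand for slow clearance and higher numbers for fast clearance), compound 1 gives the lowest of the three numbers; the step of a 1.6-fold higher number from compound 1 to compound 3 (0.21 log units; within the scatter) lies within the scatter, while the step of a 2.4-fold higher number from compound 1 to compound 2 (0.38 log units; beyond the scatter) lies beyond it. Compound 4 `O=S(=O)(c1ccc(F)c(Cl)c1)c1cnc2cc(F)ccc2c1-c1ccccc1F` differs from compound 1 by 2-fluorophenyl in place of 3-fluorophenyl on an aromatic carbon. Every measured step alters the aryl group on the sulfonyl sulfur, as in a 1.5-fold lower number from compound 2 to compound 3 (0.17 log units; within the scatter), so none bears directly on a change at this other position, and the data give no guide to its size. The step of no change at the digits printed from compound 1 to compound 4 (within the scatter) is therefore expected to stay within the scatter, with no clear direction. Compound 4 is expected to give about 0.25 mL/min, estimated between 0.12 mL/min and 0.5 mL/min.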

Compound 4, intrinsic clearance in a liver preparation (reported as CLH), per the amount of preparation that the assay uses: 1.07 mL/min
For compound 4 the middle estimate is 4.3-fold (0.63 log units) below the measured one, and the stated range ends below it.
By their numbers in this assay, from the lowest: compounds 1, 3, 2 and 4 (each within the scatter of the next, the first and the last beyond it).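

In this assay, 2-fluorophenyl in place of 3-fluorophenyl gives a 4.3-fold higher number from compound 1 to compound 4 (0.63 log units; beyond the scatter). This is the first step shown at this position, and it shows that clearance here responds to the place of the fluorine alone, with the same atoms on both sides of the change. Nothing available explains this shift. From the compounds shown here alone, it remains open whether the step would hold with 3,4-difluorophenyl or 3,5-dichlorophenyl on the sulfonyl sulfur. Going by these compounds, how a plain phenyl or a methoxyphenyl group would read at this position is also open.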